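Swapping a sulfonyl linker for an amide on a shared core

The compounds below may be only part of what the source reports. "The series", "measured", "known", "first", "only" and "open" are said of these compounds alone.

Of the compounds shown here, three built on the same core have been tested in a functional assay on A-375 cells (Homo sapiens) for cytotoxicity, read by MTT assay; on this read-out lower numbers stand for stronger inhibition and higher numbers for weaker inhibition. Compound 1, `O=S(=O)(NCCNc1nccc(-c2c(-c3cccc(F)c3)nc3sccn23)n1)c1ccc(Cl)cc1`, carries a (4-chlorophenyl)sulfonyl group on an amine nitrogen and gives 18600 nM, the highest number of the three. Compound 2, `O=C(NCCNc1nccc(-c2c(-c3cccc(F)c3)nc3sccn23)n1)c1ccc(Cl)cc1`, replaces that sulfonyl with a (4-chlorophenyl)carbonyl group and gives 2570 nM. Compound 3, `O=C(NCCCNc1nccc(-c2c(-c3cccc(F)c3)nc3sccn23)n1)c1ccc(Cl)cc1`, keeps the carbonyl but lengthens the chain by one carbon and gives 13700 nM.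

The step of a 7.2-fold lower number from compound 1 to compound 2 (0.86 log units; beyond the scatter) shows that the change from sulfonyl to carbonyl lowered the number well beyond the scatter. The step of a 5.3-fold higher number from compound 2 to compound 3 (0.73 log units; beyond the scatter) shows that the longer chain raised it again, and the step of a 1.4-fold lower number from compound 1 to compound 3 (0.13 log units; within the scatter) is within the scatter.

Compound 4, `Cc1ccc(C(=O)NCCNc2nccc(-c3c(-c4cccc(F)c4)nc4sccn34)n2)cc1`, differs from compound 1 in this way: (4-methylphenyl)carbonyl in place of (4-chlorophenyl)sulfonyl on an amine nitrogen. The chain length stays as in compound 1 and compound 2, so the sulfonyl-to-carbonyl change seen in a 7.2-fold lower number from compound 1 to compound 2 (0.86 log units; beyond the scatter) is the step that bears most directly on it. For the measured compounds named here, nothing among the measured compounds shows what swapping the chlorine for a methyl on the phenyl ring does, so that part is uncertain. The expectation is therefore a step of about a 5.3-fold lower number from compound 1 to compound 4 (0.73 log units; beyond the scatter), landing compound 4 near compound 2. Compound 4 is estimated at 3500 nM, in a range from 1200 nM to 10000 nM.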

Compound 4, half-maximal inhibitory concentration: 5880 nM
For compound 4 the middle estimate is 1.7-fold (0.23 log units) below the measured one, and the stated range covers the measured number.
By their numbers in this assay, from the lowest: compound 2; then compound 4; then compounds 3 and 1 (each within the scatter of the next).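

For the compounds shown here, with the chain and the amide left as they were, methyl in place of chloro on an aromatic carbon gives a 2.3-fold higher number from compound 2 to compound 4 (0.36 log units; beyond the scatter) and is the first read-out of what this ring group does, so the chlorine-bearing compound 2 keeps the lowest number so far. The amide with the methyl group still improves on the sulfonyl with the chlorine, with a 3.2-fold lower number from compound 1 to compound 4 (0.50 log units; beyond the scatter) showing that the gain seen for the amide survives this ring change, although this step alters both features at once and cannot separate them. The remaining step, a 2.3-fold lower number from compound 3 to compound 4 (0.37 log units; beyond the scatter) alongside a shorter chain, also mixes chain length with the ring group and cannot be read as the effect of either one alone.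

Open questions include whether a methoxy or trifluoromethyl group on that aromatic carbon would bring the number below that of compound 2, and whether the methyl-for-chloro step would look the same on the longer chain of compound 3 or with the sulfonyl of compound 1. Nothing available explains why any of these numbers shift.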